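A Dichlorophenyl Amide Weighed Against Two Limits

The source may report more compounds than this note shows. Statements on the series, on what has been measured and on what is new or still open speak of the compounds shown alone.

Compound 1 `COc1ccc2nc(C)cc(OCC(=O)NCc3cc(C)cc(C)c3)c2c1`: > 100000 nM
Compound 2 `COc1ccc2nc(C)cc(OCC(=O)Nc3cc(C)c(F)c(C)c3)c2c1`: > 100000 nM

Of the compounds shown here, two sharing one core have been tested in a toxicity assay on HepG2 cells (Homo sapiens) for inhibition, read by CellTiter-Glo, with a stated time of 48 h; on this read-out higher numbers stand for weaker inhibition and lower numbers for stronger inhibition. Compound 1 reaches only the limit of the assay, > 100000 nM, which is a limit and not a number. Compound 2 likewise stops at a limit, > 100000 nM. The step that the two limits leave unreadable from compound 1 to compound 2 therefore cannot be read. Where compound 2 stands is told only by the limit of > 100000 nM in this assay, at which 2 of the 2 values shown sit, so its position is a limit and nothing finer.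

Compound 3 `COc1ccc2nc(C)cc(OCC(=O)Nc3ccc(Cl)cc3Cl)c2c1` differs from compound 2 in one place: 2,4-dichlorophenyl in place of 4-fluoro-3,5-dimethylphenyl on an amide-type nitrogen. Going by the values given here, no measured step bears on this change; the single step between the measured compounds is hidden by the two limits, so its size is unknown and offers no guide in this assay. The data point to no direction, so no step beyond the scatter is expected. Compound 3 is therefore estimated at 100000 nM, with a range from 30000 nM to 300000 nM. The step of a number no higher from compound 2 to compound 3 (the limit leaves the size open) is expected to be flat, and a reading that again ends at a limit is the likeliest outcome.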

Compound 3, half-maximal inhibitory concentration: > 100000 nM
Compound 3: only a limit was reported; the forecaster's own chance of this, stated with the estimate: 75%; the middle value sits exactly at the limit.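

Compound 3 ends at > 100000 nM in this assay, which is a limit and not a number. Going by these compounds alone, no step among compound 1, compound 2 and compound 3 can therefore be read, and the three share one position: the limit of > 100000 nM in this assay, at which 3 of the 3 values shown sit. The compounds shown leave open whether any change on the amide-type nitrogen alters the true value in this assay.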